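Putting an ethyl on the acid: what one step teaches

This account rests on a few compounds, and the source may have more. Where it says the series, first, only, none or still open, it means among the compounds named here.

Four compounds share one core and differ at the free acid. Compound 1 `COc1ccc(/C=C/C(=O)O)c(OC(=O)c2nc(C)c(C)nc2C)c1` and compound 2 `COc1ccc(OC(=O)c2nc(C)c(C)nc2C)c(/C=C/C(=O)O)c1` both carry that acid; the difference between the two cores is not broken down here. In a functional assay on EA.hy 926 cells (Homo sapiens) for cytotoxicity, read by MTT assay, with stated times of 24 h and 12 h, tested at 12.5 uM (a lower number here means a weaker effect, a higher number a stronger effect of the compound at the concentration tested), compound 1 gives 39.7%, and compound 2 gives 21.7%. Compound 3 `CCOC(=O)/C=C/c1ccc(OC)cc1OC(=O)c1nc(C)c(C)nc1C` is compound 1 with ethyl in place of hydrogen on an oxygen next to a carbonyl group, and in this assay compound 3 gives -57.6%, which is a number 97.3 percentage points lower from compound 1 to compound 3 (beyond the scatter).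

Compound 4 `CCOC(=O)/C=C/c1cc(OC)ccc1OC(=O)c1nc(C)c(C)nc1C` is not yet measured. It stands to compound 2 as compound 3 stands to compound 1: the change is ethyl in place of hydrogen on an oxygen next to a carbonyl group, at the same place, so it is the same change made on the other core. Going by the values given here, the expected step of a number 66.7 percentage points lower from compound 2 to compound 4 (beyond the scatter) in this assay is set beside the measured one, because a number 97.3 percentage points lower from compound 1 to compound 3 (beyond the scatter) is the only guide to what this change does, and it rests on a single pair. With that in mind, compound 4 is estimated at -45%, with a range from -95% to 5%, before the measurement is known.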

Compound 4, a percentage reported as activity, at one concentration (the size of the read-out at that concentration, not a potency): 15.9%
Compound 4: middle estimate off by 60.9 percentage points, on the low side; measured number outside the range, above it.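

In this assay, the change that turns the carboxy group into ethoxycarbonyl, ethyl in place of hydrogen, gives on the core of compound 2 a number 5.8 percentage points lower from compound 2 to compound 4 (within the scatter). On this core, then, the change has no effect that can be told apart from ordinary repeat-to-repeat variation, and the large step seen on the other core does not carry over: the same change on two cores in this assay, a number 97.3 percentage points lower (beyond the scatter) from compound 1 to compound 3 and a number 5.8 percentage points lower (within the scatter) from compound 2 to compound 4, 91.5 percentage points apart, beyond the scatter of two such steps. Going by these compounds alone, this shows that the effect of the change depends on the core it is made on, but with only two pairs it does not show why the cores behave differently, nor whether any other change would depend on the core in the same way.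

The compounds shown carry only a free acid or an ethyl ester at this place, so it stays open how a methyl ester, a longer chain or an amide would behave there. As far as these compounds go, it also stays open whether such groups would split the two cores apart as ethyl does.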